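Swapping the Amide Ring in a Cathepsin S Series

The source may report more compounds than this note shows. Statements on the series, on what has been measured and on what is new or still open speak of the compounds shown alone.

Two measured compounds share a core that is varied only in the ring attached to one carbonyl carbon. Compound 1 `N#CC1(NC(=O)[C@@H]2C[C@@H](S(=O)(=O)c3ccccc3)C[C@H]2C(=O)N2CCCCC2)CC1` gives 0.8 nM in an assay on isolated protein for inhibition of cathepsin S (Homo sapiens), read by fluorescence, with a stated time of 20 min; a higher number here means a weaker inhibitor, a lower number a stronger inhibitor. Compound 2 `CN1CCN(C(=O)[C@@H]2C[C@H](S(=O)(=O)c3ccccc3)C[C@H]2C(=O)NC2(C#N)CC2)CC1` gives 2 nM in this assay, the highest of the two numbers available; its nearest neighbour is compound 1, and the step of a 2.5-fold higher number from compound 1 to compound 2 (0.40 log units; beyond the scatter) is modest though beyond the scatter. Compound 3 `N#CC1(NC(=O)[C@@H]2C[C@@H](S(=O)(=O)c3ccccc3)C[C@H]2C(=O)N2CCS(=O)(=O)CC2)CC1` has not yet been measured. It differs from compound 2 by 1,1-dioxothiomorpholin-4-yl in place of 4-methylpiperazin-1-yl on a carbonyl carbon. For the measured compounds named here, the only measured step that bears on this position is a 2.5-fold higher number from compound 1 to compound 2 (0.40 log units; beyond the scatter), which shows that exchanging one six-membered non-aromatic ring on the carbonyl carbon for another moved the number only modestly. Going by the values given here, no measured step involves the entering group, so the direction of the change is uncertain, and a small step, within or just beyond the scatter, is expected. For compound 3 the estimate in this assay is 2.5 nM, with a range from 0.8 nM to 8 nM. This expectation corresponds to an estimated step of a 1.3-fold higher number from compound 2 to compound 3 (0.10 log units; within the scatter).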

Compound 3, half-maximal inhibitory concentration: 4 nM
Estimate against measurement, compound 3: 1.6-fold (0.20 log units) below; the measured number falls inside the stated range.
By their numbers in this assay, from the lowest: compound 1; then compounds 2 and 3 (each within the scatter of the next).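

In this assay, putting 1,1-dioxothiomorpholin-4-yl in place of 4-methylpiperazin-1-yl on the carbonyl carbon gives a 2.0-fold higher number from compound 2 to compound 3 (0.30 log units; within the scatter), so these two rings cannot be told apart here, even though the entering ring carries sulfur and oxygen and the leaving ring carries neither. Set against piperidin-1-yl, the same ring gives a 5.0-fold higher number from compound 1 to compound 3 (0.70 log units; beyond the scatter), which leaves compound 1 with the lowest number of the three, its steps to both others lying beyond the scatter. Within these three compounds, the position therefore takes either six-membered ring with two hetero atoms at only a modest cost relative to piperidin-1-yl.

Nothing available accounts for these differences in terms of mechanism or of any measured property. Still open, as far as these compounds go, is how the number would respond to morpholin-4-yl, to a smaller ring such as pyrrolidin-1-yl, or to an open-chain amine such as dimethylamino on the same carbonyl carbon, and whether piperidin-1-yl would keep its place among them.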